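Iodo in place of methoxy: expectation for compound 4

The compounds below may be only part of what the source reports. "The series", "measured", "known", "first", "only" and "open" are said of these compounds alone.

In a functional assay on K-562R cells (Homo sapiens) for cytotoxicity, read by XTT assay, with a stated time of 24 h (a higher number here means a weaker inhibitor, a lower number a stronger inhibitor), compound 3 `COc1cc(C(=O)Nc2ccc(C)c(Nc3nccc(-c4cccnc4)n3)c2)ccc1OCCCCn1ccnc1` gives 27100 nM. This is within the scatter of compound 1 `Cc1ccc(NC(=O)c2ccc(OCCCCn3ccnc3)c(Br)c2)cc1Nc1nccc(-c2cccnc2)n1`, which gives 31800 nM. Compound 2 `Cc1ccc(NC(=O)c2ccc(OCCCCn3ccnc3)cc2)cc1Nc1nccc(-c2cccnc2)n1` stands higher at 99400 nM.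

Compound 4 `Cc1ccc(NC(=O)c2ccc(OCCCCn3ccnc3)c(I)c2)cc1Nc1nccc(-c2cccnc2)n1` carries iodo in place of methoxy on an aromatic carbon, ortho to a 4-(1H-imidazol-1-yl)butoxy group: iodo in place of methoxy on an aromatic carbon.

The closest measured change, bromo to methoxy, is a 1.2-fold lower number from compound 1 to compound 3 (0.07 log units; within the scatter), within the scatter. The two steps involving hydrogen, a 3.1-fold higher number from compound 1 to compound 2 (0.49 log units; beyond the scatter) and a 3.7-fold lower number from compound 2 to compound 3 (0.56 log units; beyond the scatter), are modest and beyond it. For the measured compounds named here, no iodo compound has yet been measured, so this rests on the bromo compound alone.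

The estimated 1.1-fold higher number from compound 3 to compound 4 (0.03 log units; within the scatter) lies within the scatter, with no direction expected. Compound 4 is estimated at 29000 nM, with an expected range of 14000 nM to 60000 nM.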

Compound 4, half-maximal inhibitory concentration: 52400 nM
Compound 4: the middle estimate sits 1.8-fold (0.26 log units) below what was measured, within the range that was stated.
By their numbers in this assay, from the lowest: compounds 3, 1, 4 and 2 (each within the scatter of the next, the first and the last beyond it).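

In this assay, iodo at this position, ortho to a 4-(1H-imidazol-1-yl)butoxy group, cannot be told apart from methoxy (a 1.9-fold higher number from compound 3 to compound 4 (0.29 log units; within the scatter)), bromo (a 1.6-fold higher number from compound 1 to compound 4 (0.22 log units; within the scatter)) or hydrogen (a 1.9-fold lower number from compound 2 to compound 4 (0.28 log units; within the scatter)). Bromo and methoxy each stood beyond the scatter of hydrogen, whereas iodo does not, so the gain seen with those two groups is not clearly shared by this larger halogen. Nothing measured here accounts for this result.

Open, as far as these compounds go, is whether an amine or a carboxylic acid at this position would move beyond the scatter of compound 3. Also open, from the compounds shown here alone, is whether a longer chain in place of the 4-(1H-imidazol-1-yl)butoxy group would shift the series.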